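The source may report more compounds than this note shows. Statements on the series, on what has been measured and on what is new or still open speak of the compounds shown alone.

Measured so far in a functional assay on WHCO1 cells (Homo sapiens) for cytotoxicity, read by MTT assay, with a stated time of 24 h; on this read-out lower numbers stand for stronger inhibition and higher numbers for weaker inhibition:
- compound 1 `C=CC(O)C1=CC(=O)c2ccccc2C1=O` gives 4300 nM
- compound 2 `O=C1C=C(C(O)c2ccccc2)C(=O)c2ccccc21` gives 3900 nM
- compound 3 `O=C1C=C(C(O)c2ccc(Cl)cc2)C(=O)c2ccccc21` gives 3000 nM

Compound 3 sits at the lower end of these three numbers, but its separation from the others is within the scatter: a 1.3-fold lower number from compound 2 to compound 3 (0.11 log units; within the scatter) and a 1.4-fold lower number from compound 1 to compound 3 (0.16 log units; within the scatter). Compound 4 `Cc1cc(Cl)ccc1C(O)C1=CC(=O)c2ccccc2C1=O` differs from compound 3 by methyl in place of hydrogen on an aromatic carbon. For the measured compounds named here, the only step that bears on a change on this aromatic ring is a 1.3-fold lower number from compound 2 to compound 3 (0.11 log units; within the scatter), and the other step, a 1.1-fold lower number from compound 1 to compound 2 (0.04 log units; within the scatter), is also within the scatter; no measured pair shows a change beyond it. The expected step in this assay is therefore none beyond the scatter, no change at the digits printed from compound 3 to compound 4 (within the scatter). Compound 4 is estimated at 3000 nM, in the range 1500 nM to 6000 nM.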

Compound 4, half-maximal inhibitory concentration: 3400 nM
Compound 4: the middle estimate sits 1.1-fold (0.05 log units) below what was measured, and the stated range covers the measured number.
By their numbers in this assay, from the lowest: compounds 3, 4, 2 and 1 (each within the scatter of the next).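

In this assay methyl in place of hydrogen on an aromatic carbon, ortho to a large group and meta to a chloro group, gives a 1.1-fold higher number from compound 3 to compound 4 (0.05 log units; within the scatter). For the compounds shown here, this position therefore tolerates one added carbon alongside the chloro group without a step beyond the scatter, which the earlier compounds, none substituted here, could not show. Nothing available explains this result. On these data alone, whether an amine, a carboxylic acid or a longer chain at this place would give a step beyond the scatter remains open.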